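Rearranging one ring group: from compound 3 to compound 4

The source may report more compounds than this note shows. Statements on the series, on what has been measured and on what is new or still open speak of the compounds shown alone.

Three measured compounds share one core and differ only in the ring group on a double-bonded chain carbon. In a functional assay on MCF7 cells (Homo sapiens) for antiproliferative activity, read by CellTiter-Glo, with a stated time of 5 days (on this read-out higher numbers stand for weaker inhibition and lower numbers for stronger inhibition), compound 1 `CC/C(=C(/c1ccc(/C=C/C(=O)O)cc1)c1ccc2[nH]ncc2c1)c1ccccc1` gives 7.2 nM. Compound 2 `CC/C(=C(/c1ccc(/C=C/C(=O)O)cc1)c1ccn2nccc2c1)c1ccccc1` gives > 500 nM, which is a limit of the assay and not a number. Compound 3 `CC/C(=C(/c1ccc(/C=C/C(=O)O)cc1)c1ccc2nccn2c1)c1ccccc1` gives 170 nM, the higher of the two actual numbers.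

Compound 4 `CC/C(=C(/c1ccc(/C=C/C(=O)O)cc1)c1ccn2ccnc2c1)c1ccccc1` has not yet been measured. It holds the same atoms as compound 3, joined differently: a group of 9 heavy atoms (7 carbon, 2 nitrogen; one five-membered aromatic ring with 2 hetero atoms, one six-membered aromatic ring with 1 hetero atom) in place of a group of 9 heavy atoms (7 carbon, 2 nitrogen; one five-membered aromatic ring with 2 hetero atoms, one six-membered aromatic ring with 1 hetero atom), on a double-bonded chain carbon bound to an aromatic carbon and a double-bonded chain carbon.

For the measured compounds named here, all the measured steps bear on this change, since each one alters only this group. Moving away from the group of compound 1 was costly, with a 24-fold higher number from compound 1 to compound 3 (1.37 log units; beyond the scatter) and an at least 69-fold higher number from compound 1 to compound 2 (1.84 log units; beyond the scatter), both large. Going by the values given here, the closest precedent is the swap between two groups of matching make-up, with an at least 2.9-fold lower number from compound 2 to compound 3 (0.46 log units; beyond the scatter), which is beyond the scatter. Such a rearrangement can therefore matter, but its direction here cannot be read from one example.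

In this assay the expected result is a 1.5-fold higher number from compound 3 to compound 4 (0.17 log units; within the scatter), so no step beyond the scatter is expected, although a weaker result is somewhat more likely than a stronger one. Compound 4 is estimated at 250 nM, with an expected range of 50 nM to 1000 nM.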

Compound 4, half-maximal inhibitory concentration: > 500 nM
Compound 4: only a limit was reported (the forecaster's own chance of this, stated with the estimate: 35%); middle value at least 2.0-fold (0.30 log units) away from the limit.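

In this assay there is an at least 2.9-fold higher number from compound 3 to compound 4 (0.46 log units; beyond the scatter), so a second rearrangement of the same atoms also moves the result beyond the scatter, this time towards weaker inhibition, whereas the step from compound 2 to compound 3 went towards stronger inhibition. For the compounds shown here, the reading for compound 4 is a limit of the assay and not a number, so how much weaker it is cannot be told, only that the step is at least modest. With an at least 69-fold higher number from compound 1 to compound 4 (1.84 log units; beyond the scatter), compound 4 also stands as far from compound 1 as the limit allows, and among the four groups shown, the large gains in this assay belong to compound 1 alone, the only one whose six-membered aromatic ring is of carbon only.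

How compound 2 and compound 4 compare cannot be read, since both sit at the same limit: the limit of > 500 nM in this assay, at which 2 of the 4 values shown sit.

Still open, on these data alone, is whether a small addition, such as a fluorine or a methyl on the ring group of compound 3, would shift the number in either direction at this position.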